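The source may hold more compounds than are shown below. What is called first, only, known or untested is meant among the compounds shown, and "the series" means these compounds.

Measured so far:
Compound 1, `CCOc1ncc(-c2nc(C(F)(F)F)sc2N2CCN(C(=O)Cn3cnc4cccnc43)[C@H](C)C2)cn1`, gives 2 nM in a functional assay on CHO-K1 cells for antagonist activity at C-X-C chemokine receptor type 3 (Homo sapiens), read by FLIPR, with a stated time of 10 min; a higher number here means a weaker inhibitor, a lower number a stronger inhibitor.
Compound 2, `CCOc1ncc(-c2nc(C(F)(F)F)sc2N2CCN(C(=O)Cn3nccc3C)[C@H](C)C2)cn1`, gives 2 nM in this assay.
Compound 3, `CCOc1ncc(-c2nc(C(F)(F)F)sc2N2CCN(C(=O)Cn3ccc(C(F)(F)F)n3)[C@H](C)C2)cn1`, gives 3.8 nM in this assay.

All three compounds share one core and differ only in the small aromatic ring attached to the saturated chain carbon bound to the carbonyl carbon. Compound 3 carries the highest number of the three, but the two steps that lead to it are a 1.9-fold higher number from compound 1 to compound 3 (0.28 log units; within the scatter) and a 1.9-fold higher number from compound 2 to compound 3 (0.28 log units; within the scatter), so these three values cannot be told apart. The remaining step, no change at the digits printed from compound 1 to compound 2 (within the scatter), shows the same picture: three quite different rings at this position give the same inhibition.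

Compound 4, `CCOc1ncc(-c2nc(C(F)(F)F)sc2N2CCN(C(=O)Cn3cc(Cl)cn3)[C@H](C)C2)cn1`, keeps the core and changes the ring once more: 4-chloro-1H-pyrazol-1-yl in place of 3-(trifluoromethyl)-1H-pyrazol-1-yl on a saturated chain carbon bound to a carbonyl carbon. Among the measured compounds shown here, the step most like it is the one from compound 2 to compound 3, where one substituent on the same pyrazole ring was exchanged for another, and that step stayed within the scatter. Nothing in the three measured steps points to a shift beyond the scatter for this assay in either direction.

Compound 4 is therefore expected to land close to compound 3, at 3 nM, with a likely range from 1.5 nM to 8 nM, which means an estimated step of a 1.3-fold lower number from compound 3 to compound 4 (0.10 log units; within the scatter).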

Compound 4, half-maximal inhibitory concentration: 5.1 nM
The estimate for compound 4 lay 1.7-fold (0.23 log units) below the measured number; the range from low to high includes it.
By their numbers in this assay, from the lowest: compounds 1, 2, 3 and 4 (each within the scatter of the next, the first and the last beyond it).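

In this assay, among the compounds shown here, this position is no longer entirely flat: 4-chloro-1H-pyrazol-1-yl gives the first steps beyond the scatter, both modest (a 2.6-fold higher number from compound 2 to compound 4 (0.41 log units; beyond the scatter) and a 2.6-fold higher number from compound 1 to compound 4 (0.41 log units; beyond the scatter)). The same group stays within the scatter against the trifluoromethyl pyrazole (a 1.3-fold higher number from compound 3 to compound 4 (0.13 log units; within the scatter)), so compound 3 cannot be separated from either end of the series, and the four numbers form a shallow slope rather than two distinct groups. Nothing measured here explains why this small difference appears.

The step from compound 2 to compound 4 changes both the substituent and its place on the pyrazole, so the unsubstituted 1H-pyrazol-1-yl and the 4-methyl and 3-chloro pyrazoles would be needed to tell those two changes apart. Every group shown at this position is also an aromatic ring, which leaves open what a morpholine, another saturated amine or a carboxylic acid would give on the saturated chain carbon bound to the carbonyl carbon.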